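Working notes: methyl in place of methoxy, compound 4

A few compounds are considered here, and "the series" means these few. Any claim that something is new, unique, unknown or untested is made for them only; others in the source may bear on it.

Compound 1, `COc1ccccc1/C=C1\NS(=O)(=O)c2ccccc2C1=O`: 2590 nM in an assay for inhibition of alkaline phosphatase, tissue-nonspecific isozyme (Homo sapiens), read by spectrophotometry, with stated times of 10 min and 20 min; on this read-out higher numbers stand for weaker inhibition and lower numbers for stronger inhibition
Compound 2, `O=C1/C(=C/c2ccc(Br)cc2)NS(=O)(=O)c2ccccc21`: 1430 nM in this assay
Compound 3, `O=C1/C(=C/c2c(F)cccc2F)NS(=O)(=O)c2ccccc21`: 1530 nM in this assay

Compound 1 carries the highest number of the three, but its gaps to compound 3 and to compound 2 both fall within the scatter, so no order among the three measured compounds can be read from these numbers.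

Compound 4, `Cc1ccccc1/C=C1\NS(=O)(=O)c2ccccc2C1=O`, has not yet been measured. It differs from compound 1 in one place: methyl in place of methoxy on an aromatic carbon. Among the compounds with values here, no measured pair covers this change, so the expectation rests on compound 1 alone. The expected step is small, not beyond the scatter in either direction: a 1.1-fold lower number from compound 1 to compound 4 (0.05 log units; within the scatter). Compound 4 is therefore expected near 2300 nM, with a range from 900 nM to 6000 nM.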

Compound 4, half-maximal inhibitory concentration: 2360 nM
Compound 4: the middle estimate sits 1.0-fold (0.01 log units) below what was measured, and the stated range covers the measured number.
By their numbers in this assay, from the lowest: compounds 2, 3, 4 and 1 (each within the scatter of the next).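

Methyl in place of methoxy on this aromatic carbon, ortho to a large group, gives a 1.1-fold lower number from compound 1 to compound 4 (0.04 log units; within the scatter), so losing the oxygen, and with it the hydrogen-bond acceptor, leaves no readable change in this assay. 2-methylphenyl in place of 4-bromophenyl gives a 1.7-fold higher number from compound 2 to compound 4 (0.22 log units; within the scatter), again no readable change. No available evidence bears on these two results.

From the compounds shown here alone, whether an amine or a carboxylic acid on this aromatic carbon would move the number beyond the scatter remains open. Both steps here lie within the scatter, so the series does not yet show which changes at this position matter.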